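Moving the chlorine: 4-chlorobenzyl to 2-chlorobenzyl

This account rests on a few compounds, and the source may have more. Where it says the series, first, only, none or still open, it means among the compounds named here.

Measured so far in an ADME assay on HeLa cells (Homo sapiens) for cytotoxicity, read by MTT assay (a higher number here means a weaker inhibitor, a lower number a stronger inhibitor), and still open:
- compound 1 `COC(=O)[C@@H]1CCCN1C(=O)CCC(=O)Oc1ccc(C[C@H]2C(=O)OC[C@@H]2Cc2ccc(OC)c(OC)c2)cc1OC` gives 145000 nM
- compound 2 `COc1ccc(C[C@H]2COC(=O)[C@@H]2Cc2ccc(OCc3cn(Cc4ccc(Cl)cc4)nn3)c(OC)c2)cc1OC` gives 242000 nM
- compound 3 `COC(=O)[C@H](CC(C)C)NC(=O)CCC(=O)Oc1ccc(C[C@H]2C(=O)OC[C@@H]2Cc2ccc(OC)c(OC)c2)cc1OC` gives 53200 nM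
- compound 4 `COc1ccc(C[C@H]2COC(=O)[C@@H]2Cc2ccc(OCc3cn(Cc4ccccc4Cl)nn3)c(OC)c2)cc1OC` has no value yet

Compound 2 at 242000 nM lies within the scatter of compound 1 at 145000 nM. Compound 3 gives 53200 nM, and compound 2 stands higher than it by more than the scatter. From compound 2 to compound 4, 2-chlorophenyl takes the place of 4-chlorophenyl on a saturated chain carbon bound to an aromatic nitrogen, counted as 2-chlorophenyl in place of 4-chlorophenyl on a saturated chain carbon bound to an aromatic nitrogen in full. Among the measured compounds shown here, the single measured step shows a 2.7-fold lower number from compound 1 to compound 3 (0.44 log units; beyond the scatter) and is modest, but it concerns a different substituent on a carbonyl carbon. For the measured compounds named here, no measured pair moves a chlorine, so the data give no direct guide to this change. In this assay no step beyond the scatter is therefore expected. The estimate amounts to a 1.1-fold lower number from compound 2 to compound 4 (0.04 log units; within the scatter) as the expected step. Compound 4 is expected at 220000 nM with an estimated range from 100000 nM to 450000 nM for now.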

Compound 4, half-maximal inhibitory concentration: 84500 nM
Beside the measured number, compound 4's estimate is 2.6-fold (0.42 log units) above it; the measured number lies below the stated range.
By their numbers in this assay, from the lowest: compounds 3, 4, 1 and 2 (each within the scatter of the next, the first and the last beyond it).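

In this assay, 2-chlorobenzyl in place of 4-chlorobenzyl gives a 2.9-fold lower number from compound 2 to compound 4 (0.46 log units; beyond the scatter). The two compounds have the same atoms and the same counts of donors, acceptors and charge in the changed group, so the series responds beyond the scatter to where the chlorine sits, not only to which group is attached, as in the earlier step on the carbonyl carbon. No supporting measurement explains this step.

This is a single pair on one shared core, so it sets no rule for other groups on the ring of this benzyl substituent. Plain benzyl, or a carboxylic acid in place of the chlorine, would show whether the step depends on chlorine itself or holds for other groups.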